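Swapping Butyl for a Fluorinated Phenyl on the Triazole

The source may hold more compounds than are shown below. What is called first, only, known or untested is meant among the compounds shown, and "the series" means these compounds.

Of the compounds shown here, three sharing one core have been tested in an ADME assay on HEK293 cells (Homo sapiens) for cytotoxicity, read by sulforhodamine B assay, with a stated time of 48 h, tested at 10 uM; on this read-out higher numbers stand for more inhibition at the one concentration tested (going by the name of the read-out) and lower numbers for less inhibition. Compound 1 `CCCCc1cn(C(c2ccccc2)c2cc3cc(Br)ccc3nc2OC)nn1` gives -3.47%, the smallest of the three numbers shown, although both other compounds lie within the scatter of it. Compound 2 `COc1nc2ccc(Br)cc2cc1C(c1ccccc1)n1cc(-c2ccccc2F)nn1` gives 3.97%, and compound 3 `CCOC(=O)c1cn(C(c2ccccc2)c2cc3cc(Br)ccc3nc2OC)nn1` gives 2%. The steps of a number 7.4 percentage points higher from compound 1 to compound 2 (within the scatter) and a number 5.5 percentage points higher from compound 1 to compound 3 (within the scatter) both stay within the scatter, as does a number 2 percentage points lower from compound 2 to compound 3 (within the scatter); in short, none of the three groups tried so far moved the read-out in a meaningful way.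

Compound 4 `COc1nc2ccc(Br)cc2cc1C(c1ccccc1)n1cc(-c2ccccc2C(F)(F)F)nn1` has not yet been measured. It differs from compound 1 by 2-(trifluoromethyl)phenyl in place of butyl on an aromatic carbon. The measured step that most resembles this change is a number 7.4 percentage points higher from compound 1 to compound 2 (within the scatter), where a different group on the same aromatic carbon, 2-fluorophenyl, replaced butyl without leaving the scatter. Because a number 7.4 percentage points higher from compound 1 to compound 2 (within the scatter) and a number 5.5 percentage points higher from compound 1 to compound 3 (within the scatter) were both small, no step beyond the scatter is expected for compound 4. Compound 4 is therefore estimated at 3%, within -8% to 14%, which corresponds to an expected step of a number 6.5 percentage points higher from compound 1 to compound 4 (within the scatter).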

Compound 4, a percentage reported as inhibition, at one concentration (the size of the read-out at that concentration, not a potency): 14.3%
Compound 4: middle estimate off by 11.3 percentage points, on the low side; the whole stated range lies below it.
By their numbers in this assay, from the lowest: compounds 1, 3 and 2 (each within the scatter of the next); then compound 4.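

In this assay this aromatic carbon now shows a real response: 2-(trifluoromethyl)phenyl in place of butyl gives a number 17.8 percentage points higher from compound 1 to compound 4 (beyond the scatter) and, set against ethoxycarbonyl, gives a number 12.3 percentage points higher from compound 3 to compound 4 (beyond the scatter) on the same carbon. Even the smallest change, trifluoromethyl in place of fluoro on the phenyl ring, gives a number 10.3 percentage points higher from compound 2 to compound 4 (beyond the scatter) while compound 2 stays within the scatter of compound 1, so a phenyl ring at this carbon is not enough on its own, and the group it carries makes the difference. No measurement shown here accounts for this rise.

As far as these compounds go, whether the rise needs fluorine at all remains open, and a 2-methylphenyl group on this carbon would help to settle that. Also open, from the compounds shown here alone, is how a carboxylic acid or an amine at this carbon would read.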